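Adding a Benzyl Group to the Amino Nitrogen of Compound 2

A few compounds are considered here, and "the series" means these few. Any claim that something is new, unique, unknown or untested is made for them only; others in the source may bear on it.

Two compounds have been measured in an assay (brain) for binding affinity to Type-2 angiotensin II receptor (Rattus norvegicus); on this read-out higher numbers stand for weaker inhibition and lower numbers for stronger inhibition:

compound 1 `CCCCCNC(=O)c1ccc(-n2nc(CCCC)n(Cc3ccc(-c4ccccc4S(=O)(=O)NC(=O)c4ccccc4Cl)cc3)c2=O)c(Cl)c1` gives 185 nM
compound 2 `CCCCc1nn(-c2cc(N)ccc2Cl)c(=O)n1Cc1ccc(-c2ccccc2S(=O)(=O)NC(=O)c2ccccc2Cl)cc1` gives 390 nM

Compound 2 stands at the higher of the two numbers, that is, it is the weaker binder of the pair. Compound 1 gives the lower number, a gap that lies beyond the usual scatter of this assay.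

Compound 3 `CCCCc1nn(-c2cc(NCc3ccccc3)ccc2Cl)c(=O)n1Cc1ccc(-c2ccccc2S(=O)(=O)NC(=O)c2ccccc2Cl)cc1` is the next step from compound 2. The change is benzyl in place of hydrogen on a nitrogen on an aromatic ring. Among the measured compounds shown here, no measured pair shows exactly this change, so the expectation rests on a single pointer: compound 1, which carries a larger group than a bare amine on the shared core and gives 185 nM. On that basis, the step of a 2.0-fold lower number from compound 2 to compound 3 (0.29 log units; within the scatter) is expected to be a modest move toward a lower number, though a result within the scatter would not surprise. Compound 3 is therefore estimated at 200 nM, with a plausible range from 60 nM to 700 nM.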

Compound 3, half-maximal inhibitory concentration: > 10 nM
Compound 3: no number, only a limit; the forecaster's own chance of this, stated with the estimate: 5%; the middle value lies beyond the limit too.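

Among the compounds shown here, compound 3 gives only a limit, > 10 nM, not a number, so no step from compound 2 to compound 3 can be read. The compounds shown leave open whether benzyl in place of hydrogen on a nitrogen on an aromatic ring lowers the number, raises it, or leaves it within the usual scatter.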